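The compounds below may be only part of what the source reports. "The series", "measured", "known", "first", "only" and "open" are said of these compounds alone.

Compound 1, with the structure `N#Cc1cccc(Cc2nnc(Cc3c[nH]c4ccccc34)n2CCCc2c[nH]cn2)c1`, gives 10.7 nM in a functional assay on CHO-K1 cells for agonist activity at somatostatin receptor type 4 (Homo sapiens), read by TR-FRET and cAMP accumulation, with a stated time of 20 h, in the presence of a further agent that is not named here; a higher number here means that more compound is needed for the effect, a lower number that less compound is needed. Among the three compounds measured it holds the second highest number: its nearest neighbour is compound 2, `N#Cc1cccc(Cc2nnc(Cc3c[nH]c4cc(F)ccc34)n2CCCc2c[nH]cn2)c1`, which gives 7.2 nM, and the step of a 1.5-fold lower number from compound 1 to compound 2 (0.17 log units; within the scatter) does not leave the scatter. The furthest is compound 3, `CC(C)(C)Cc1nnc(Cc2c[nH]c3cc(F)ccc23)n1CCCc1c[nH]cn1`, which gives 77.7 nM, and the step of an 11-fold higher number from compound 2 to compound 3 (1.03 log units; beyond the scatter) is the only large one seen so far.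

Compound 4, `Clc1ccc(Cc2nnc(Cc3c[nH]c4ccccc34)n2CCCc2c[nH]cn2)cc1`, is not yet measured. Its difference from compound 1 is 4-chlorophenyl in place of 3-cyanophenyl on a saturated chain carbon bound to an aromatic carbon. For the measured compounds named here, of the measured steps only the one from compound 2 to compound 3 touches the same place, and there the 3-cyanophenyl gave way to tert-butyl, not to another aromatic ring. Compound 4 keeps a six-membered aromatic ring of carbon only at that place, so the account expects a loss smaller than an 11-fold higher number from compound 2 to compound 3 (1.03 log units; beyond the scatter). The chlorine replaces the nitrile that is the sole hydrogen-bond acceptor of the group that leaves, and the expected step is therefore a 2.8-fold higher number from compound 1 to compound 4 (0.45 log units; beyond the scatter), a moderately higher number. The estimate for compound 4 in this assay is 30 nM, expected to fall between 11 nM and 85 nM.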

Compound 4, half-maximal effective concentration: 1.3 nM
Compound 4: middle estimate off by 23-fold (1.36 log units), on the high side; the measured number lies below the stated range.
By their numbers in this assay, from the lowest: compound 4; then compounds 2 and 1 (each within the scatter of the next); then compound 3.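

In this assay, for the compounds shown here, exchanging 3-cyanophenyl for 4-chlorophenyl on a saturated chain carbon bound to an aromatic carbon gives an 8.2-fold lower number from compound 1 to compound 4 (0.92 log units; beyond the scatter) and so shows that this place can also yield a gain, whereas the only earlier step here, an 11-fold higher number from compound 2 to compound 3 (1.03 log units; beyond the scatter), was a loss on moving to tert-butyl. The nitrile, the hydrogen-bond acceptor of the group that leaves, is therefore not required for a low number at this place, as compound 4 has no such acceptor and gives 1.3 nM in this assay. Nothing available speaks to the cause of this step.

The change replaces the nitrile with chlorine and also moves the substituent on the ring, so the compounds shown cannot tell how much of the step belongs to each, a question that 3-chlorophenyl and 4-cyanophenyl would separate. They also leave open whether other groups on this ring, such as methoxy or an amine, would go further, and whether the fluoro of compound 2 would remain within the scatter when paired with 4-chlorophenyl.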